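A few compounds are considered here, and "the series" means these few. Any claim that something is new, unique, unknown or untested is made for them only; others in the source may bear on it.

Measured in an ADME assay on DLD-1 cells (Homo sapiens) for antiproliferative activity, read by luminescence, with a stated time of 3 days; on this read-out lower numbers stand for stronger inhibition of growth and higher numbers for weaker inhibition of growth:
Compound 1 `CC(C)C1=C(C(=O)N2[C@H](C)CC[C@H]2C(=O)N2CCN(C)C3(CC3)C2)SC2=N[C@@](C)(c3ccc(Cl)cc3)[C@@H](c3ccc(Cl)cc3)N21`: 17200 nM
Compound 2 `CC(C)C1=C(C(=O)N2[C@H](C)CC[C@H]2C(=O)N2CCNC3(CC3)C2)SC2=N[C@@](C)(c3ccc(Cl)cc3)[C@@H](c3ccc(Cl)cc3)N21`: 16200 nM

These two compounds differ in one place, an amine nitrogen in a ring, and the step is a 1.1-fold lower number from compound 1 to compound 2 (0.03 log units; within the scatter). Within the data shown here, compound 2, at 16200 nM, therefore stands level with its only neighbour, and the two cannot be ranked.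

Compound 3 `CC(C)C1=C(C(=O)N2[C@H](C)CC[C@H]2C(=O)N2CCNC3(CC3)C2)SC2=N[C@@](C)(c3ccc(Cl)cc3)[C@@H](c3ccc(Cl)c(F)c3)N21` departs from compound 2 elsewhere in the molecule: fluoro in place of hydrogen on an aromatic carbon. This is fluoro in place of hydrogen on an aromatic carbon, so a 4-chlorophenyl becomes 4-chloro-3-fluorophenyl. Among the measured compounds shown here, no measured pair carries a change on that ring. For the measured compounds named here, the single available step, a 1.1-fold lower number from compound 1 to compound 2 (0.03 log units; within the scatter), lies at a different place and offers only a weak guide. With no closer evidence, no step beyond the scatter is expected in this assay, and no direction can be favoured. The expected change is a 1.1-fold lower number from compound 2 to compound 3 (0.03 log units; within the scatter). For compound 3 the estimated value is 15000 nM, with an expected range of 8000 nM to 28000 nM.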

Compound 3, concentration for 50% growth inhibition in the DLD-1 assay: 16700 nM
Compound 3: the middle estimate sits 1.1-fold (0.05 log units) below what was measured; measured number inside the range.
By their numbers in the DLD-1 assay, from the lowest: compounds 2, 3 and 1 (each within the scatter of the next).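

Among these compounds, in the DLD-1 assay the result gives a 1.0-fold higher number from compound 2 to compound 3 (0.01 log units; within the scatter) for fluoro in place of hydrogen on an aromatic carbon, ortho to a chloro group, so a first change on this 4-chlorophenyl ring, which the earlier pair left untouched, brings no step that can be read beyond the scatter. The same change can also be followed in a physicochemical assay for solubility, read by HPLC, in phosphate buffer, at pH 6.8, tested at 10 mM (a lower number here means a less soluble compound, a higher number a more soluble compound), where it gives a 1.1-fold lower number from compound 2 to compound 3 (0.04 log units; within the scatter), with compound 2 at 56 ug/mL and compound 3 at 51 ug/mL standing level, so neither read-out separates the 4-chloro-3-fluorophenyl compound from its 4-chlorophenyl partner. Nothing measured here offers an explanation for either result.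

The compounds shown leave open whether a larger group on this carbon, such as methoxy, trifluoromethyl or an amine, would bring a step beyond the scatter on either read-out. They also leave open whether fluoro on the other 4-chlorophenyl ring would behave in the same way, since the single step shown here covers only one carbon on one ring.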